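Returning to a Fluorinated Pyridine While Keeping an Amine

A few compounds are considered here, and "the series" means these few. Any claim that something is new, unique, unknown or untested is made for them only; others in the source may bear on it.

Measured so far in an in vitro assay on HEK385-7 cells for displacement of a labelled ligand from prostaglandin D2 receptor 2 (Homo sapiens); a lower number here means a stronger inhibitor, a higher number a weaker inhibitor:
- compound 1 `O=C(O)Cc1sc(C(c2ccc(F)cc2)c2ccc(F)cc2)nc1-c1ccnc(F)c1` gives 0.48 nM
- compound 2 `O=C(O)Cc1sc(C(c2ccc(F)cc2)c2ccc(F)cc2)nc1-c1ccnc(N2CCC2)c1` gives 660 nM
- compound 3 `Cc1cc(-c2nc(C(c3ccc(F)cc3)c3ccc(F)cc3)sc2CC(=O)O)cnc1N` gives 880 nM

Compound 3 has the highest number of the three, but its gap to compound 2 lies within the scatter, so the two cannot be ranked; only compound 1 stands clearly apart, with a 1800-fold higher number from compound 1 to compound 3 (3.26 log units; beyond the scatter).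

Compound 4 `Nc1cc(-c2nc(C(c3ccc(F)cc3)c3ccc(F)cc3)sc2CC(=O)O)cc(F)n1` is the next step from compound 3: 2-amino-6-fluoropyridin-4-yl in place of 6-amino-5-methylpyridin-3-yl on an aromatic carbon. The entering group, 2-amino-6-fluoropyridin-4-yl, carries the fluoro of compound 1 and the amino of compound 3. Going by the values given here, two measured steps bear on this. Replacing fluoro with a larger amine cost a 1400-fold higher number from compound 1 to compound 2 (3.14 log units; beyond the scatter), and swapping the whole fluoropyridine for the aminomethylpyridine cost a 1800-fold higher number from compound 1 to compound 3 (3.26 log units; beyond the scatter). From the compounds shown here alone, compound 4 keeps the fluoro, so a substantial recovery toward compound 1 is expected, tempered by the added amino, whose effect is untested. The expected step is an 88-fold lower number from compound 3 to compound 4 (1.94 log units; beyond the scatter), placing compound 4 at an estimated 10 nM, within 1 nM to 200 nM.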

Compound 4, half-maximal inhibitory concentration: 220 nM
Beside the measured number, compound 4's estimate is 22-fold (1.34 log units) below it; measured number outside the range, above it.
By their numbers in this assay, from the lowest: compound 1; then compound 4; then compounds 2 and 3 (each within the scatter of the next).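

Compound 4 differs from compound 1 only by an amino group in place of a hydrogen on the pyridine, and that single addition gives a 460-fold higher number from compound 1 to compound 4 (2.66 log units; beyond the scatter), so keeping the fluoro does not by itself preserve the low number of compound 1. Moving to the 2-amino-6-fluoropyridin-4-yl group still gives real but modest gains, namely a 4.0-fold lower number from compound 3 to compound 4 (0.60 log units; beyond the scatter) and a 3.0-fold lower number from compound 2 to compound 4 (0.48 log units; beyond the scatter), which are small beside the loss that comes with the amino group. No supporting measurement bears on why this amino group costs so much.

From the compounds shown here alone, it remains open whether a hydroxyl or a methoxy group in place of this amino would cost as much. Going by these compounds, it is also open whether a chloro could stand in for the fluoro of compound 1.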